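Pyrimidin-2-yl on the aromatic nitrogen: cytotoxicity notes

This account rests on a few compounds, and the source may have more. Where it says the series, first, only, none or still open, it means among the compounds named here.

compound 1 `CCCCCn1nc(C(=O)N[C@H]2COc3ccccc3N(C)C2=S)nc1Cc1ccccc1`: > 100000 nM
compound 2 `CC(C)Cn1nc(C(=O)N[C@H]2COc3ccccc3N(C)C2=S)nc1Cc1ccccc1`: > 100000 nM
compound 3 `CN1C(=S)[C@@H](NC(=O)c2nc(Cc3ccccc3)n(CC3COC3)n2)COc2ccccc21`: > 100000 nM

In a toxicity assay on HT-29 cells (Homo sapiens) for cytotoxicity (on this read-out higher numbers stand for lower toxicity in this test and lower numbers for higher toxicity in this test), compound 3 gives > 100000 nM, which is a limit and not a number. It shares this position with the other two measured compounds: the limit of > 100000 nM in this assay, at which 3 of the 3 values shown sit.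

Compound 4 `CN1C(=S)[C@@H](NC(=O)c2nc(Cc3ccccc3)n(-c3ncccn3)n2)COc2ccccc21` differs from compound 3 by pyrimidin-2-yl in place of (oxetan-3-yl)methyl on an aromatic nitrogen. The change places pyrimidin-2-yl in place of (oxetan-3-yl)methyl on an aromatic nitrogen, next to the ring atom that bears a benzyl group.

The measured steps nearest to this change are a step that the two limits leave unreadable from compound 1 to compound 2, a step that the two limits leave unreadable from compound 1 to compound 3 and a step that the two limits leave unreadable from compound 2 to compound 3. Among the compounds with values here, all three exchange one saturated group for another, and no measured compound carries an aromatic ring at this place, so they give only weak guidance. The expectation rests mainly on compound 3 with its limit of > 100000 nM.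

No step beyond the usual scatter is expected in this assay, and the estimated step is a number no higher from compound 3 to compound 4 (the limit leaves the size open). If a number is reported instead of a limit, its direction would be towards higher toxicity in this test. For compound 4 the estimated value is 100000 nM, with an expected range from 40000 nM to 150000 nM.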

Compound 4, half-maximal cytotoxic concentration: > 100000 nM
Compound 4: only a limit was reported; the forecaster's own chance of this, stated with the estimate: 85%; the middle value lies on the limit itself.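

Compound 4 reports a limit, as do compound 1, compound 2 and compound 3, so no step to compound 4 can be read in this assay: the limit of > 100000 nM in this assay, at which 4 of the 4 values shown sit.

The compounds shown leave open how far apart these four lie, and whether any group on this aromatic nitrogen would give a numerical cytotoxic concentration.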